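Trading the hydroxyl-bearing ring for an oxygen-containing one

The source may report more compounds than this note shows. Statements on the series, on what has been measured and on what is new or still open speak of the compounds shown alone.

Of the compounds shown here, three sharing one core have been measured in an assay on isolated protein for inhibition of protein kinase C theta type (Homo sapiens), read by TR-FRET, with a stated time of 2 h; a higher number here means a weaker inhibitor, a lower number a stronger inhibitor. Compound 2 `N#Cc1cnc(NCc2cnccc2C(F)(F)F)cc1N[C@H]1CC[C@H](O)CC1` gives 350 nM, the lowest of the three numbers. Among the compounds with values here, compound 1 `N#Cc1cnc(NCc2cnccc2C(F)(F)F)cc1NC[C@H]1C[C@H](O)C1` gives 700 nM, and the only single-point step available, a 2.0-fold lower number from compound 1 to compound 2 (0.30 log units; within the scatter), lies within the scatter. Within the data shown here, compound 3 `N#Cc1cnc(NCc2ccccc2C(F)(F)F)cc1N[C@H]1CC[C@H](O)CC1` gives 4000 nM, a higher number than compound 2 by a gap that is beyond the scatter, but no single step connects it to the change now under consideration.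

The new compound 4 `N#Cc1cnc(NCc2cnccc2C(F)(F)F)cc1NC1CCOCC1` differs from compound 2 by oxan-4-yl in place of 4-hydroxycyclohexyl on a nitrogen on an aromatic ring. The one donor on the saturated ring departs while an acceptor remains within the ring itself. Among the measured compounds shown here, no measured step reproduces this swap: the step from compound 1 to compound 2 exchanged one hydroxyl-bearing substituent for another and barely moved the number, which only shows that the shape of this substituent is tolerated. How much the hydroxyl contributes is not tested by any pair here.

Without a direct precedent, a modest move toward a weaker number is expected, a 2.3-fold higher number from compound 2 to compound 4 (0.36 log units; beyond the scatter), with a real chance that it falls within the scatter. Compound 4 is therefore estimated at 800 nM, between 250 nM and 2500 nM.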

Compound 4, half-maximal inhibitory concentration: 900 nM
Beside the measured number, compound 4's estimate is 1.1-fold (0.05 log units) below it; low and high end bracket the measured number.
By their numbers in this assay, from the lowest: compounds 2, 1 and 4 (each within the scatter of the next, the first and the last beyond it); then compound 3.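

In this assay, within the data shown here, oxan-4-yl in place of 4-hydroxycyclohexyl on a nitrogen on an aromatic ring gives a 2.6-fold higher number from compound 2 to compound 4 (0.41 log units; beyond the scatter) and is the first single-place step at this position to lie beyond the scatter, though only modestly. The other step to the new compound, a 1.3-fold higher number from compound 1 to compound 4 (0.11 log units; within the scatter), stays within the scatter, so oxan-4-yl and (3-hydroxycyclobutyl)methyl cannot be told apart here even though only the latter carries a hydrogen-bond donor, and a donor on this substituent is therefore not required for a number in this range. No measurement on hand accounts for the step from compound 2 to compound 4.

Oxan-4-yl differs from 4-hydroxycyclohexyl in more than the donor, and the compounds shown do not separate those differences; a plain cyclohexyl group, or a 4-aminocyclohexyl group with an amine where the hydroxyl stands, would bear on that. From the compounds shown here alone, it also remains open whether the same exchange gives a step of similar size on the core of compound 3.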